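The source may report more compounds than this note shows. Statements on the series, on what has been measured and on what is new or still open speak of the compounds shown alone.

Of the compounds shown here, three have so far been tested in a functional assay on MCF7 cells (Homo sapiens) for antiproliferative activity, read by MTT assay, with a stated time of 48 h; a higher number here means a weaker inhibitor, a lower number a stronger inhibitor. Compound 1 `COc1ccc(OC)c(/C=N/c2c(C#N)ncn2-c2ccc(F)cc2)c1` gives 7090 nM, compound 2 `COc1cc(/C=N/c2c(C#N)ncn2-c2ccc(F)cc2)ccc1O` gives 9990 nM, and compound 3 `COc1ccc(OC)c(/C=N/c2c(C#N)ncn2Cc2ccc(F)cc2)c1` gives 10900 nM. How the core of compound 1 differs from the core of compound 2 is not broken down here. Compound 3 arises from compound 1 by a single change, (4-fluorobenzyl in place of 4-fluorophenyl on an aromatic nitrogen), and that step made a 1.5-fold higher number from compound 1 to compound 3 (0.19 log units; within the scatter). Compound 4 `COc1cc(/C=N/c2c(C#N)ncn2Cc2ccc(F)cc2)ccc1O` has not yet been measured; it arises from compound 2 by the same change, (4-fluorobenzyl in place of 4-fluorophenyl on an aromatic nitrogen). Among the compounds with values here, compound 4 is expected to show a 1.4-fold higher number from compound 2 to compound 4 (0.15 log units; within the scatter) in this assay because the one earlier example of this change gave a 1.5-fold higher number from compound 1 to compound 3 (0.19 log units; within the scatter). The estimate for compound 4 is therefore 14000 nM, most likely falling between 7000 nM and 28000 nM.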

Compound 4, half-maximal inhibitory concentration: 11400 nM
Estimate against measurement, compound 4: 1.2-fold (0.09 log units) above; low and high end bracket the measured number.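

Placing 4-fluorobenzyl in place of 4-fluorophenyl on the aromatic nitrogen gave a 1.1-fold higher number from compound 2 to compound 4 (0.06 log units; within the scatter) in this assay. Set beside the earlier example, the change looks alike on the two cores: the same change on two cores in this assay, a 1.5-fold higher number (0.19 log units; within the scatter) from compound 1 to compound 3 and a 1.1-fold higher number (0.06 log units; within the scatter) from compound 2 to compound 4, 1.3-fold (0.13 log units) apart, within the scatter of two such steps. Within the data shown here, this agreement shows only that on these two cores the change stays within ordinary scatter; with steps this small, it does not show that the change has a real effect, or that a third core would respond the same way.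

The compounds shown leave open whether a different group on that aromatic nitrogen, such as a longer chain ending in an amine or a carboxylic acid, would move the number beyond the scatter.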